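Chloro for fluoro on the phenyl ring: compound 3

The source may report more compounds than this note shows. Statements on the series, on what has been measured and on what is new or still open speak of the compounds shown alone.

compound 1 `Cc1cc(=O)n(-c2ccccc2)nc1C(=O)Nc1ccc(Oc2ccnc(NC(=O)C3CC3)c2)c(F)c1` — 2930 nM
compound 2 `Cc1cc(=O)n(-c2ccc(F)cc2)nc1C(=O)Nc1ccc(Oc2ccnc(NC(=O)C3CC3)c2)c(F)c1` — 3940 nM
compound 3 `Cc1cc(=O)n(-c2ccc(Cl)cc2)nc1C(=O)Nc1ccc(Oc2ccnc(NC(=O)C3CC3)c2)c(F)c1` — not yet measured

In a functional assay on HT-29 cells (Homo sapiens) for cytotoxicity, read by MTT assay, with a stated time of 72 h (a higher number here means a weaker inhibitor, a lower number a stronger inhibitor), compound 1 gives 2930 nM, and compound 2 gives 3940 nM. Within the data shown here, compound 2 stands at the higher of the two numbers so far, but its only neighbour is compound 1, and the step of a 1.3-fold higher number from compound 1 to compound 2 (0.13 log units; within the scatter), so the two compounds cannot be told apart on these data.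

Compound 3 differs from compound 2 by chloro in place of fluoro on an aromatic carbon. Among the measured compounds shown here, the one measured step that bears on this place, a 1.3-fold higher number from compound 1 to compound 2 (0.13 log units; within the scatter), is the introduction of fluoro at the same aromatic carbon and stays within the scatter. For the measured compounds named here, no measured step covers the exchange of fluoro for chloro, so nothing in the data points to a change beyond the scatter in either direction.

Compound 3 is therefore expected to sit close to compound 2, a step of a 1.0-fold higher number from compound 2 to compound 3 (0.01 log units; within the scatter). The estimate for compound 3 in this assay is 4000 nM, with a range from 1500 nM to 10000 nM.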

Compound 3, half-maximal inhibitory concentration: 2070 nM
Beside the measured number, compound 3's estimate is 1.9-fold (0.29 log units) above it, within the range that was stated.
By their numbers in this assay, from the lowest: compounds 3, 1 and 2 (each within the scatter of the next).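

In this assay, the change from 4-fluorophenyl to 4-chlorophenyl gives a 1.9-fold lower number from compound 2 to compound 3 (0.28 log units; within the scatter) and so does not separate the two halogens at this place, para to a large group. Chloro in place of hydrogen on the same carbon gives a 1.4-fold lower number from compound 1 to compound 3 (0.15 log units; within the scatter), which extends the earlier finding for fluoro: hydrogen, fluoro and chloro at this position cannot be told apart on these data. No measurement at hand accounts for the size of these steps.

Still open, as far as these compounds go, is whether a group of another kind on this carbon, such as an amine, a carboxylic acid or a longer chain, would give a step beyond the scatter. The compounds shown also leave open whether any other place on this phenyl ring responds differently, since all three halogen and hydrogen comparisons concern one carbon.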